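Swapping bromo for fluoro on the aryl ring of compound 1

This account rests on a few compounds, and the source may have more. Where it says the series, first, only, none or still open, it means among the compounds named here.

Measured compounds:
- compound 1, `COc1cccc(Nc2nccc(-c3ccc(Br)cc3)n2)c1`: 977 nM
- compound 2, `COc1cccc(Nc2nccc(-c3ccc(Cl)c(Cl)c3)n2)c1`: 741 nM
- compound 3, `O=[N+]([O-])c1ccc(Nc2nccc(-c3ccc(Cl)c(Cl)c3)n2)cc1`: 573 nM

All three compounds share the same core, an anilino-pyrimidine carrying an aryl ring, and were tested in an assay on isolated protein for inhibition of phosphatidylinositol 4,5-bisphosphate 3-kinase catalytic subunit beta isoform (Homo sapiens); on this read-out higher numbers stand for weaker inhibition and lower numbers for stronger inhibition. Compound 1 shows the highest of the three numbers, but its gap to compound 2 and its gap to compound 3 both sit inside the usual scatter of repeated measurements, so the three compounds cannot be placed in any order of strength; they read as roughly alike. Among the compounds with values here, no pair among them differs in a single place, so no measured step is available to lean on.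

Compound 4, `COc1cccc(Nc2nccc(-c3ccc(F)cc3)n2)c1`, has not yet been measured. It differs from compound 1 in one place: fluoro in place of bromo on an aromatic carbon. Fluoro is the smallest of the halogens, and in this series the nearest comparison, compound 2 with two chloro groups, gives 741 nM, close to compound 1. Since nothing in the data shows a large effect from changing the halogen, a modest move toward a higher number is expected, with the step from compound 1 to compound 4 in this assay estimated as a 1.5-fold higher number from compound 1 to compound 4 (0.19 log units; within the scatter). Compound 4 is therefore expected to give about 1500 nM, within a range of 600 nM to 4000 nM.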

Compound 4, half-maximal inhibitory concentration: > 1000 nM
Compound 4 was reported as a limit (the forecaster's own chance of this, stated with the estimate: 10%); the middle value lies beyond the limit too.
By their numbers in this assay, from the lowest: compounds 3, 2 and 1 (each within the scatter of the next). At a limit, above all of these: compound 4.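

Within the data shown here, the change from 4-bromophenyl to 4-fluorophenyl is the first in this set made at a single place, and in this assay it reads as an at least 1.0-fold higher number from compound 1 to compound 4 (0.01 log units; that floor lies within the scatter). Compound 4 is reported as a limit, > 1000 nM, and not as a number. Fluoro on this aromatic carbon therefore gives no sign of a lower number than bromo, but the true size of the step cannot be read, and it could be negligible or large, as the comparison stops at the edge of what the assay reports: the limit of > 1000 nM in this assay, at which 1 of the 4 values shown sits.

The compounds shown leave open how far the number of compound 4 lies past its limit, and so whether the choice of halogen at this place matters at all. They also leave open what a group other than a halogen would do on this aromatic carbon, such as an amine, a nitrile or a carboxylic acid, any of which could be set in place of the bromo of compound 1.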